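Swapping the Alkyne Chain for a Saturated Chain

The compounds below may be only part of what the source reports. "The series", "measured", "known", "first", "only" and "open" are said of these compounds alone.

Among the measured compounds shown here, compound 1 `CCCCCC#Cc1cn([C@H]2C[C@H](O)[C@@H](CO)O2)c(=O)[nH]c1=O` is the only compound with a number in a functional assay on L1210 cells (Mus musculus); a higher number here means a weaker inhibitor, a lower number a stronger inhibitor: compound 1 gives 219 ug/mL. Compound 2 `CCC#Cc1cn(C2O[C@H](CO)[C@@H](O)[C@@H]2O)c(=O)[nH]c1=O` gives a limit in this assay, > 1000 ug/mL, and no number; (the limit of > 1000 ug/mL in this assay, at which 1 of the 2 values shown sits). Compound 3 `CCCCCCc1cn([C@H]2C[C@H](O)[C@@H](CO)O2)c(=O)[nH]c1=O` is not yet measured. The change from compound 1 to compound 3 is hexyl in place of hept-1-yn-1-yl on an aromatic carbon. For the measured compounds named here, no measured pair shows a change of this kind, so the expectation rests on compound 1 alone. Compound 3 is expected to be a somewhat weaker inhibitor, with the step of a 2.3-fold higher number from compound 1 to compound 3 (0.36 log units; beyond the scatter) likely beyond the scatter but uncertain in size. Compound 3 is estimated at 500 ug/mL, between 150 ug/mL and 1500 ug/mL.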

Compound 3, concentration for 50% inhibition: 301 ug/mL
Beside the measured number, compound 3's estimate is 1.7-fold (0.22 log units) above it; the range from low to high includes it.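

At this aromatic carbon, a saturated chain can stand in for the alkyne chain with no difference that can be told from the scatter in this assay, with a 1.4-fold higher number from compound 1 to compound 3 (0.14 log units; within the scatter). In this pair, then, inhibition does not depend on the triple bond, although the chain also loses one carbon in the same step, so the two changes cannot be separated. Nothing measured here explains this result.

Still open, as far as these compounds go, is how a longer chain, such as octyl, or a much shorter one, such as ethyl, would read at this position. An amine or a carboxylic acid at the end of the hexyl chain is equally untested among the compounds shown.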